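The source may report more compounds than this note shows. Statements on the series, on what has been measured and on what is new or still open speak of the compounds shown alone.

Measured so far in a physicochemical assay for solubility, read by HPLC, with a stated time of 4 h, at pH 7; a lower number here means a less soluble compound, a higher number a more soluble compound:
Compound 1 `CCc1ccc(NC(=O)Nc2ccc(OC[C@@]3(C)Cn4cc([N+](=O)[O-])nc4O3)cc2)cc1` gives < 1 ug/mL, which is a limit of the assay.
Compound 2 `C[C@]1(COc2ccc(N3CCN(S(=O)(=O)c4ccc(C(F)(F)F)cc4)CC3)cc2)Cn2cc([N+](=O)[O-])nc2O1` gives < 1 ug/mL, also a limit.
Compound 3 `COc1ccc(NC(=S)Nc2ccc(OC[C@@]3(C)Cn4cc([N+](=O)[O-])nc4O3)cc2)cc1` gives 8.66 ug/mL.

Compound 1 stands at the limit of < 1 ug/mL in this assay, at which 2 of the 3 values shown sit; only a limit is known for it, not a number. Compound 3 is the one of the three with a measured number. Compound 4 `CCOc1ccc(NC(=O)Nc2ccc(OC[C@@]3(C)Cn4cc([N+](=O)[O-])nc4O3)cc2)cc1` differs from compound 1 by ethoxy in place of ethyl on an aromatic carbon, para to a large group. Within the data shown here, no pair among the measured compounds differs in just one place, so no measured step shows what this change does to solubility. Compound 1 sits at the limit of < 1 ug/mL in this assay, at which 2 of the 3 values shown sit, so a modest rise would carry compound 4 into the measurable range, while a fall or no change would leave it at the limit again. The step from compound 1 to compound 4 is expected to be an at least 1.5-fold higher number from compound 1 to compound 4 (0.17 log units; that floor lies within the scatter), a small upward one. Compound 4 is estimated at 1.5 ug/mL, within 0.4 ug/mL to 6 ug/mL, with a real chance that only a limit is reported.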

Compound 4, solubility: 6.66 ug/mL
Compound 4: middle estimate off by 4.4-fold (0.65 log units), on the low side; the whole stated range lies below it.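

Compound 1 stands at a limit, not a number, in this assay: the limit of < 1 ug/mL in this assay, at which 2 of the 4 values shown sit.

Compound 1 and compound 4 are the only pair shown that differ in one place, so this is the one direct reading of a change at this position, on an aromatic carbon, para to a large group. Putting ethoxy in place of ethyl gives an at least 6.6-fold higher number from compound 1 to compound 4 (0.82 log units; beyond the scatter), a step known only as a floor, and it brings the series from the limit into the measurable range with the rest of the molecule unchanged.

This single pair cannot show whether the same swap would do the same on another core or at another place on the ring. Going by these compounds, whether a longer chain such as propoxy, an amine or a carboxylic acid at this carbon would raise the number further also remains open.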